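Bromine for Chlorine on Two Related Cores

A few compounds are considered here, and "the series" means these few. Any claim that something is new, unique, unknown or untested is made for them only; others in the source may bear on it.

Compound 1 `COc1cccc(C2=CC(c3ccc(Cl)cc3)NC(=S)N2)c1` and compound 2 `COc1cccc(C2=CC(c3ccc(Br)cc3)NC(=S)N2)c1` share one core, while compound 3 `COc1cccc(C2=NNC(c3ccc(Cl)cc3)C2O)c1` and compound 4 `COc1cccc(C2=NNC(c3ccc(Br)cc3)C2O)c1` share another; the difference between the two cores is not broken down here. In a functional assay on HepG2 cells (Homo sapiens) for antiproliferative activity, read by sulforhodamine B assay, with a stated time of 48 h (a lower number here means a stronger inhibitor, a higher number a weaker inhibitor), compound 1 gives 54 nM, and compound 2 gives 34 nM. In this assay compound 3 gives 35.3 nM, a number that lies within the scatter of both compound 1 and compound 2. The change from compound 1 to compound 2 is bromo in place of chloro on an aromatic carbon, and it produced a 1.6-fold lower number from compound 1 to compound 2 (0.20 log units; within the scatter), a step too small to count as a real change. Compound 4 carries the same change on the other core, (bromo in place of chloro on an aromatic carbon), at a place described in identical words, and it has not yet been measured. The expectation is that the new step will look like the earlier one, and that rests on compound 1 and compound 2, where a 1.6-fold lower number from compound 1 to compound 2 (0.20 log units; within the scatter). The expected step is a 1.4-fold lower number from compound 3 to compound 4 (0.13 log units; within the scatter). Compound 4 is therefore estimated at 26 nM, most likely between 13 nM and 52 nM.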

Compound 4, half-maximal inhibitory concentration: 43 nM
For compound 4 the middle estimate is 1.7-fold (0.22 log units) below the measured one; the range from low to high includes it.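

In this assay, bromo in place of chloro on the second core gave a 1.2-fold higher number from compound 3 to compound 4 (0.09 log units; within the scatter), so here too the step is too small to count as a real change. The two steps also cannot be told apart from each other: the same change on two cores in this assay, a 1.6-fold lower number (0.20 log units; within the scatter) from compound 1 to compound 2 and a 1.2-fold higher number (0.09 log units; within the scatter) from compound 3 to compound 4, 1.9-fold (0.29 log units) apart, within the scatter of two such steps. In these two pairs, then, the change from 4-chlorophenyl to 4-bromophenyl behaves alike on both cores, leaving the number within the scatter each time, but this agreement is only an absence of any visible effect: it does not show that a larger effect would carry from one core to the other, and it says nothing about other assays.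

The compounds shown leave open whether a clearly different group at the same place, such as an amine, a carboxylic acid or a longer chain, would move the number beyond the scatter on either core. If one did, it would remain to be seen whether the size of that step matched on both cores.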